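Replacing phenyl with cyclohexyl on the ring amide nitrogen

This account rests on a few compounds, and the source may have more. Where it says the series, first, only, none or still open, it means among the compounds named here.

Values in a functional assay on HepG2 cells (Homo sapiens) for antiproliferative activity, read by MTT assay, with a stated time of 72 h; a lower number here means a stronger inhibitor, a higher number a weaker inhibitor:
- compound 1 `O=C1COc2ccc(-c3cnc(Cl)c(NS(=O)(=O)c4ccc(F)cc4)c3)cc2N1c1ccc(F)cc1`: > 40000 nM (a limit)
- compound 2 `CC(C)N1C(=O)COc2ccc(-c3cccc(NS(=O)(=O)c4ccc(F)cc4)c3)cc21`: > 40000 nM (a limit)
- compound 3 `O=C1COc2ccc(-c3cccc(NS(=O)(=O)c4ccc(F)cc4)c3)cc2N1c1ccccc1`: 30300 nM

Within the data shown here, compound 3 holds the only actual number in this assay, at 30300 nM. The other two results are limits and not numbers, as shown by the limit of > 40000 nM in this assay, at which 2 of the 3 values shown sit. Compound 4 `O=C1COc2ccc(-c3cccc(NS(=O)(=O)c4ccc(F)cc4)c3)cc2N1C1CCCCC1` keeps the core of compound 3 and changes one group: cyclohexyl in place of phenyl on an amide-type nitrogen in a ring. In words, this places cyclohexyl in place of phenyl on an amide-type nitrogen in a ring. Among the measured compounds shown here, the only measured step at this nitrogen is an at least 1.3-fold lower number from compound 2 to compound 3 (0.12 log units; that floor lies within the scatter). Going by these compounds, that step rests on a limit, so its true size is unknown. With so little to go on, no step beyond the scatter is expected in this assay, although a drift towards a higher number is possible and a result reported only as a limit is quite likely. The expected change is a 1.3-fold higher number from compound 3 to compound 4 (0.10 log units; within the scatter). For compound 4 the estimated value is 38000 nM, with an expected range of 18000 nM to 70000 nM.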

Compound 4, half-maximal inhibitory concentration: 35900 nM
Compound 4: the middle estimate sits 1.1-fold (0.02 log units) above what was measured, within the range that was stated.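

In this assay, replacing phenyl with cyclohexyl on the ring amide nitrogen gives a 1.2-fold higher number from compound 3 to compound 4 (0.07 log units; within the scatter), so a six-membered aromatic ring and a six-membered non-aromatic ring of carbon only cannot be told apart at this position. Against the isopropyl group the reading is an at least 1.1-fold lower number from compound 2 to compound 4 (0.04 log units; that floor lies within the scatter), a floor and not a measured size. Compound 2 is reported only as a limit, so the true size of this step cannot be read: the limit of > 40000 nM in this assay, at which 2 of the 4 values shown sit.

Open, going by these compounds, is whether a methyl group, a longer chain ending in an amine, or a carboxylic acid on this nitrogen would move the number beyond the scatter from compound 3. Compound 1 differs from the other compounds in more than one place and gives no reading on this nitrogen.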